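A few compounds are considered here, and "the series" means these few. Any claim that something is new, unique, unknown or untested is made for them only; others in the source may bear on it.

Compound 1 `O=C1CSC(c2c(Cl)cccc2Cl)N1CCN1CCCCC1`: 100%
Compound 2 `O=C1CSC(c2cccc(O)c2)N1CCN1CCCCC1`: 100%
Compound 3 `O=C1CSC(c2ccccc2[N+](=O)[O-])N1CCN1CCCCC1`: 100%

All three share one core and differ only in the group on the aromatic ring. In an ADME assay on Vero cells (Chlorocebus sabaeus) for cytotoxicity, read by neutral red uptake, tested at 25 ug/mL (a lower number here means a stronger effect, a higher number a weaker effect of the compound at the concentration tested), compound 3 gives 100%, and compound 1 and compound 2 sit at the same value within the usual scatter, so no one of them is set apart from the others.

Compound 4 `O=C1CSC(c2ccccc2Cl)N1CCN1CCCCC1` follows from compound 3 by one change: chloro in place of nitro on an aromatic carbon. Going by the values given here, no measured step of this kind exists here, so the expectation rests on the three values already in hand, which show no movement at all. The step from compound 3 to compound 4 is expected to be no change at the digits printed from compound 3 to compound 4 (within the scatter), nothing beyond the scatter. Compound 4 is therefore estimated at 100%, within a range from 90% to 100%.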

Compound 4, a percentage reported as activity, at one concentration (the size of the read-out at that concentration, not a potency): 100%
The estimate for compound 4 equals the measured number at the digits printed; the range from low to high includes it.
By their numbers in this assay, from the lowest: compounds 1, 2, 3 and 4 (each within the scatter of the next).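

In this assay, chloro in place of nitro on an aromatic carbon gives no change at the digits printed from compound 3 to compound 4 (within the scatter), so at this position, ortho to a large group, a group of one heavy atom reads the same as one of three. The wider comparisons agree, with no change at the digits printed from compound 2 to compound 4 (within the scatter) for 2-chlorophenyl in place of 3-hydroxyphenyl and no change at the digits printed from compound 1 to compound 4 (within the scatter) for hydrogen in place of chloro. Nothing measured here explains this flat result. Still open, from the compounds shown here alone, is whether an amine or a carboxylic acid on the aromatic ring would move this read-out at all.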